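This account rests on a few compounds, and the source may have more. Where it says the series, first, only, none or still open, it means among the compounds named here.

Of the compounds shown here, three built on one shared core have been measured in an assay for inhibition of sodium- and chloride-dependent glycine transporter 1 (Homo sapiens); on this read-out lower numbers stand for stronger inhibition and higher numbers for weaker inhibition. Compound 2 `Cc1ccc(Sc2ccccc2N2CC(C)N(CC(=O)O)CC2C)cc1` gives 550 nM in this assay. For the measured compounds named here, compound 3 `CC1CN(c2ccccc2Sc2ccc(F)cc2)C(C)CN1CC(=O)O` gives 1900 nM in this assay, which is the higher of the two numbers, and the step of a 3.5-fold higher number from compound 2 to compound 3 (0.54 log units; beyond the scatter) is the only single change measured so far. Compound 1 `COc1ccc(Sc2ccc(OC)cc2N2CC(C)N(CC(=O)O)CC2C)cc1` gives only a limit of this assay, > 50000 nM (the limit of > 50000 nM in this assay, at which 1 of the 3 values shown sits).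

The unmeasured compound 4 `CC(=O)Nc1ccc(Sc2ccccc2N2CC(C)N(CC(=O)O)CC2C)cc1` differs from compound 3 in one place: acetamido in place of fluoro on an aromatic carbon. Going by the values given here, the only measured step at this position, a 3.5-fold higher number from compound 2 to compound 3 (0.54 log units; beyond the scatter), swapped two small groups and gave a modest rise; nothing measured here covers an acetamido group, so the direction of this new step cannot be read from the measured steps, and a small or moderate rise seems as likely as a fall. Compound 4 is therefore expected to give about 3000 nM in this assay, with a likely range from 800 nM to 12000 nM. That expectation corresponds to the step of a 1.6-fold higher number from compound 3 to compound 4 (0.20 log units; within the scatter).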

Compound 4, half-maximal inhibitory concentration: 22000 nM
Beside the measured number, compound 4's estimate is 7.3-fold (0.87 log units) below it; the measured number lies above the stated range.
By their numbers in this assay, from the lowest: compound 2; then compound 3; then compound 4. At a limit, above all of these: compound 1.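

Acetamido in place of fluoro gives a 12-fold higher number from compound 3 to compound 4 (1.06 log units; beyond the scatter) in this assay, and acetamido in place of methyl gives a 40-fold higher number from compound 2 to compound 4 (1.60 log units; beyond the scatter), so the aromatic carbon para to a large group responds far more strongly than the modest swap of two small groups suggested. Among the three groups compared at this position, methyl gives the lowest number and acetamido the highest, each step being beyond the scatter. Nothing measured here gives a reason for the size of these steps.

The compounds leave open whether the higher number goes with the four heavy atoms of acetamido or with its hydrogen-bond donor and acceptor. An amine, a chlorine atom or a longer chain at this position would help to tell these apart.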